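Ileum antagonism series: branching the acid chain

The source may hold more compounds than are shown below. What is called first, only, known or untested is meant among the compounds shown, and "the series" means these compounds.

Measured so far:
compound 1 `CCC(CC)(CC(=O)Nc1cccc(OCc2ccc3ccccc3n2)c1)C(=O)O` in a functional assay on ileum (Cavia porcellus) for antagonist activity at cysteinyl leukotriene receptor (Homo sapiens); on this read-out higher numbers stand for weaker inhibition and lower numbers for stronger inhibition: 0.9 nM
compound 2 `O=C(O)CCC(=O)Nc1cccc(OCc2ccc3ccc(F)cc3n2)c1` in this assay: 200 nM

Compound 2 stands highest of the two numbers; its nearest neighbour, compound 1, sits far lower, a gap well beyond the scatter. Compound 3 `CCC(C)(CC(=O)Nc1cccc(OCc2ccc3ccc(F)cc3n2)c1)C(=O)O` differs from compound 2 by 1-carboxy-1-methylpropyl in place of carboxymethyl on a saturated chain carbon bound to a carbonyl carbon. Within the data shown here, no step between measured compounds is known. Given that compound 1, which carries a branched acid chain, gives 0.9 nM, a large decrease is expected from compound 2 to compound 3, estimated as a 67-fold lower number from compound 2 to compound 3 (1.82 log units; beyond the scatter). Compound 3 is expected to give 3 nM, within a range from 1 nM to 15 nM.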

Compound 3, half-maximal inhibitory concentration: 6.4 nM
Compound 3: the middle estimate sits 2.1-fold (0.33 log units) below what was measured, within the range that was stated.
By their numbers in this assay, from the lowest: compound 1; then compound 3; then compound 2.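

In this assay, 1-carboxy-1-methylpropyl in place of carboxymethyl on a saturated chain carbon bound to a carbonyl carbon gives a 31-fold lower number from compound 2 to compound 3 (1.49 log units; beyond the scatter). Among these compounds, this is the first single-place comparison; it shows that, on the core of compound 2, the read-out responds strongly to this change in the acid chain. Nothing measured here accounts for the size of the step.

Still open, going by these compounds, is how 1-carboxyethyl or 1-carboxycyclopropyl would read in place of 1-carboxy-1-methylpropyl. The compounds shown therefore do not separate the contribution of each part of the branched chain.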